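The compounds below may be only part of what the source reports. "The series", "measured", "known", "first", "only" and "open" are said of these compounds alone.

In a functional assay on DU-145 cells (Homo sapiens) for inhibition, read by trypan blue exclusion, with a stated time of 96 h (on this read-out lower numbers stand for stronger inhibition of growth and higher numbers for weaker inhibition of growth), compound 3 `Cc1ccc(S/C(=C/c2ccc(Cl)c(Cl)c2)C(=O)c2ccc(Br)cc2)cc1` stands at 50000 nM and lies within the scatter of both compound 1 `COc1ccc(/C=C(/Sc2ccc(Br)cc2)C(=O)c2ccc(Br)cc2)cc1` at 25000 nM and compound 2 `Cc1ccc(S/C(=C/c2ccc(F)c(C)c2)C(=O)c2ccc(Br)cc2)cc1` at 25000 nM in the same series. Compound 4 `COc1ccc(/C=C(/Sc2ccc(C)cc2)C(=O)c2ccc(Br)cc2)cc1` has 4-methoxyphenyl in place of 3,4-dichlorophenyl on a double-bonded chain carbon bound to a double-bonded chain carbon. The step of a 2.0-fold higher number from compound 2 to compound 3 (0.30 log units; within the scatter) is the only one measured at this place and stays within the scatter. Compound 1 also carries 4-methoxyphenyl there, though it differs elsewhere. No step beyond the scatter is therefore expected in this assay for this change. The estimated step is a 1.7-fold lower number from compound 3 to compound 4 (0.22 log units; within the scatter) and lies within the scatter. Compound 4 is estimated at 30000 nM with 12000 nM to 70000 nM as the expected range.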

Compound 4, concentration for 50% growth inhibition: 50000 nM
Beside the measured number, compound 4's estimate is 1.7-fold (0.22 log units) below it, and the stated range covers the measured number.
By their numbers in this assay, from the lowest: compounds 1, 2, 3 and 4 (each within the scatter of the next).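

At the place on a double-bonded chain carbon bound to a double-bonded chain carbon, 4-methoxyphenyl in place of 3,4-dichlorophenyl gives no change at the digits printed from compound 3 to compound 4 (within the scatter) in this assay, and a 2.0-fold higher number from compound 2 to compound 4 (0.30 log units; within the scatter) adds a further step at this place, so that all three groups there now read alike. The series also gains its first step at a second place, methyl in place of bromo on an aromatic carbon, with a 2.0-fold higher number from compound 1 to compound 4 (0.30 log units; within the scatter) in this assay as its reading. No evidence on the cause of these results is available. As far as these compounds go, whether an amine or a carboxylic acid at either place would give a step beyond the scatter remains open.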